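This account rests on a few compounds, and the source may have more. Where it says the series, first, only, none or still open, it means among the compounds named here.

Measured so far:
Compound 1 `O=C1N=C(C2C(=O)c3ccccc3C2=O)CC(c2ccccc2[N+](=O)[O-])N1`: in a functional assay on the whole organism for inhibition, with Rattus norvegicus as the target, read by paw edema, with stated times of 30 min and 4 h, at a dose of 10 mg/kg by the oral route (a lower number here means less inhibition, a higher number more inhibition at the dose given (going by the name of the read-out)), compound 1 gives 32%.
Compound 2 `O=C1N=C(C2C(=O)c3ccccc3C2=O)CC(c2ccccc2)N1`: in this assay compound 2 gives 11%.

Among the measured compounds shown here, compound 2 stands lowest of the two numbers, with compound 1 as its only neighbour. For the measured compounds named here, the single measured step, a number 21 percentage points lower from compound 1 to compound 2 (beyond the scatter), is a modest fall that goes with hydrogen in place of nitro on an aromatic carbon. Compound 3 `COc1ccc(C2CC(C3C(=O)c4ccccc4C3=O)=NC(=O)N2)cc1` differs from compound 2 by methoxy in place of hydrogen on an aromatic carbon. Going by the values given here, no measured step involves a methoxy group, so that earlier step is only a loose guide. Compound 3 is expected to show a number 9 percentage points higher from compound 2 to compound 3 (within the scatter) in this assay, a small rise at most. The estimated value of compound 3 is 20%, between 5% and 40%.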

Compound 3, a percentage reported as inhibition, in the whole organism at one dose (the size of the read-out at that dose, not a potency): 10%
For compound 3 the middle estimate is 10 percentage points above the measured one, and the stated range covers the measured number.
By their numbers in this assay, from the lowest: compounds 3 and 2 (each within the scatter of the next); then compound 1.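

In this assay, methoxy in place of hydrogen on an aromatic carbon, para to a large group, goes with a number 1 percentage points lower from compound 2 to compound 3 (within the scatter) and so does not separate the 4-methoxyphenyl compound from the phenyl one. The change from 2-nitrophenyl to 4-methoxyphenyl on a saturated ring carbon goes with a number 22 percentage points lower from compound 1 to compound 3 (beyond the scatter) and leaves compound 1 alone at the top of these three. Nothing measured here accounts for these numbers.

As far as these compounds go, what an amine or a carboxylic acid would give on that aromatic carbon remains open.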